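The source may report more compounds than this note shows. Statements on the series, on what has been measured and on what is new or still open speak of the compounds shown alone.

Of the compounds shown here, two sharing one core have been tested so far in a functional assay on V79-379A cells (Cricetulus griseus) for cytotoxicity, read by MTT assay, in the presence of a further agent that is not named here; on this read-out lower numbers stand for stronger inhibition and higher numbers for weaker inhibition. Compound 1 (`COC1=CC(=O)c2c(c(COC(=O)c3ccccc3F)c(C)n2C)C1=O`) gives 2000 nM, and compound 2 (`COC1=CC(=O)c2c(c(COCc3ccccc3)c(C)n2C)C1=O`) gives 410000 nM. Compound 2 therefore holds the higher of the two numbers, meaning the weaker inhibition, and its gap to compound 1 lies well beyond the usual scatter.

The next compound is compound 3 (`COC1=CC(=O)c2c(c(COC(C)=O)c(C)n2C)C1=O`), which has acetyl in place of benzyl on an oxygen on a saturated carbon. Among the measured compounds shown here, no measured pair shows this kind of change directly in this assay, so the forecast has little to rest on. For the measured compounds named here, the one clue is compound 1, which also has a carbonyl on that oxygen and gives 2000 nM. Compound 3 is therefore expected to sit much nearer to compound 1 than to compound 2, although a single compound is a thin guide. The expected change is a 68-fold lower number from compound 2 to compound 3 (1.83 log units; beyond the scatter), a drop towards stronger inhibition and beyond the scatter. For compound 3 the estimated value is 6000 nM, with an expected range of 1000 nM to 60000 nM.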

Compound 3, half-maximal inhibitory concentration: 2500 nM
For compound 3 the middle estimate is 2.4-fold (0.38 log units) above the measured one; low and high end bracket the measured number.
By their numbers in this assay, from the lowest: compounds 1 and 3 (each within the scatter of the next); then compound 2.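

In this assay, the step from benzyl to acetyl on this oxygen is a 160-fold lower number from compound 2 to compound 3 (2.21 log units; beyond the scatter) and counts as large, so the group carried at this position can move the number a long way. The step of a 1.3-fold higher number from compound 1 to compound 3 (0.10 log units; within the scatter) stays within the scatter, which means that exchanging 2-fluorophenyl for methyl on the carbonyl carbon makes no readable difference, and among these three compounds the two with a carbonyl on that oxygen sit together while compound 2, the one without it, stands apart. Nothing measured here explains why the numbers fall this way.

The compounds shown leave open whether the carbonyl itself separates compound 2 from the other two, or whether the removal of benzyl alone would do the same; a free hydroxyl or a plain methyl on that oxygen would help to tell these apart. Going by these compounds, it also remains open how far the carbonyl carbon tolerates other partners, such as a longer chain, an amine or a carboxylic acid.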